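The source may hold more compounds than are shown below. What is called first, only, known or untested is meant among the compounds shown, and "the series" means these compounds.

In a functional assay on NCI-H1993 cells (Homo sapiens) for inhibition, read by CCK-8 assay, with a stated time of 72 h (on this read-out lower numbers stand for stronger inhibition and higher numbers for weaker inhibition), three compounds have been measured:

Compound 1 `CC(c1c(F)cc2ncccc2c1F)n1cnc2ncc(-c3cnn(CCO)c3)nc21`: 83.7 nM
Compound 2 `CC(c1c(F)cc2ncccc2c1F)n1cnc2ncc(-c3ccncc3)nc21`: 162 nM
Compound 3 `CC(c1cc2cccnc2cc1F)n1cnc2ncc(-c3ccccc3)nc21`: 570 nM

Compound 3 has the highest of these three numbers, and its gap to each of the other two lies beyond the scatter. Compound 4 `CC(c1c(F)cc2ncccc2c1F)n1cnc2ncc(-c3ccccc3)nc21` has not been measured yet. It is compound 3 with one change: fluoro in place of hydrogen on an aromatic carbon, meta to a fluoro group already present.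

For the measured compounds named here, no measured step tests this change directly. Going by the values given here, the only step between compounds that differ in one place is a 1.9-fold higher number from compound 1 to compound 2 (0.29 log units; within the scatter), and it exchanges pyridin-4-yl for 1-(2-hydroxyethyl)-1H-pyrazol-4-yl, leaving the fluoro pattern untouched. It does show that this swap of aromatic group made little difference in that series. Compound 1 and compound 2 both carry the second fluoro and both have lower numbers than compound 3. However, each also differs from compound 3 in its aromatic group, so the two changes cannot be separated. This gives only a weak hint of direction, and a moderate fall is expected, with a 2.0-fold lower number from compound 3 to compound 4 (0.31 log units; beyond the scatter) as the estimated step. For compound 4 the estimated value is 280 nM, with an expected range of 90 nM to 800 nM.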

Compound 4, half-maximal inhibitory concentration: 514 nM
Estimate against measurement, compound 4: 1.8-fold (0.26 log units) below; the range from low to high includes it.
By their numbers in this assay, from the lowest: compounds 1 and 2 (each within the scatter of the next); then compounds 4 and 3 (each within the scatter of the next).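

In this assay, fluoro on this aromatic carbon, ortho to a fused ring and meta to a fluoro group, gives a 1.1-fold lower number from compound 3 to compound 4 (0.04 log units; within the scatter), so with phenyl as the aromatic group, compound 3 and compound 4 cannot be told apart. With the two fluoro groups held constant, the aromatic group does separate the compounds: there is a 3.2-fold higher number from compound 2 to compound 4 (0.50 log units; beyond the scatter) and also a 6.1-fold higher number from compound 1 to compound 4 (0.79 log units; beyond the scatter), so the lower numbers of compound 1 and compound 2 go with pyridin-4-yl and 1-(2-hydroxyethyl)-1H-pyrazol-4-yl in place of phenyl, not with the added fluoro. Nothing available explains either the fluoro result or the effect of the aromatic group.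

For the compounds shown here, it remains open whether the added fluoro would be equally silent in compounds carrying pyridin-4-yl or 1-(2-hydroxyethyl)-1H-pyrazol-4-yl, as the only pair that tests it carries phenyl. From the compounds shown here alone, it is also open whether a larger group on the same carbon, such as chloro, methoxy or an amine, would leave the number within the scatter as fluoro does.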